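Hydroxy for pentyl on the chain of compound 1

The source may hold more compounds than are shown below. What is called first, only, known or untested is meant among the compounds shown, and "the series" means these compounds.

In a functional assay on the whole organism (stomach) with Rattus norvegicus as the target (a lower number here means that less compound is needed, a higher number that more compound is needed for the effect), compound 1 (`CCCCCCC/N=C(\S)C1(c2ccccn2)CCCS1`) gives > 30 mg/kg as a limit, not a number. Compound 1 stands on the limit of > 30 mg/kg in this assay, at which 2 of the 3 values shown sit, and so has no readable value. Compound 2 (`CCCCCCCCCCCC/N=C(\S)C1(c2ccccn2)CCCS1`) gives > 30 mg/kg as a limit too. Within the data shown here, compound 3 (`S=C(NCc1ccccc1)C1(c2ccccn2)CCCS1`) gives <= 30 mg/kg and is likewise a limit, standing on the limit of <= 30 mg/kg in this assay, at which 1 of the 3 values shown sits, as the only compound there.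

Compound 4 (`OCC/N=C(\S)C1(c2ccccn2)CCCS1`) carries hydroxy in place of pentyl on a saturated chain carbon, two bonds along the chain from a double-bonded nitrogen. Cut one bond further out, the same difference reads hexyl to hydroxymethyl, and further still heptyl to 2-hydroxyethyl.

Among the measured compounds shown here, only one measured step bears on this chain: a step that the two limits leave unreadable from compound 1 to compound 2 adds pentyl at a place seven bonds along, and it has no readable size to carry over. For the measured compounds named here, no measured step links compound 3 to compound 1. The expectation rests on compound 1 at > 30 mg/kg as a limit, so no step beyond the scatter can be claimed in either direction. The expected step that the limit leaves unreadable from compound 1 to compound 4 is therefore only a rough estimate. The estimated value for compound 4 is 40 mg/kg with an expected range of 12 mg/kg to 120 mg/kg in this series.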

Compound 4, dose for half-maximal effect: > 30 mg/kg
Compound 4 was reported as a limit; the forecaster's own chance of this, stated with the estimate: 70%; the middle value is on the limit's open side.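

Compound 4 gives > 30 mg/kg in this assay, which is a limit and not a number. Compound 1 gives > 30 mg/kg, likewise a limit, so no step can be read between compound 1 and compound 4. The compounds shown leave open whether hydroxy in place of pentyl changes the dose needed in this assay at all.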